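The source may report more compounds than this note shows. Statements on the series, on what has been measured and on what is new or still open speak of the compounds shown alone.

Measured in a functional assay on LoVo cells (Homo sapiens) for inhibition, read by colorimetric assay and MTT assay, with a stated time of 72 h; a lower number here means a stronger inhibitor, a higher number a weaker inhibitor:
- compound 1 `C#CCCCCOc1ncc(-c2ccccc2OC)n1C`: 11000 nM
- compound 2 `C=CCCOc1ncc(-c2ccccc2OC)n1C`: 24000 nM
- compound 3 `C=CCCCCOc1ncc(-c2ccccc2OC)n1C`: 4000 nM

Compound 3 has the lowest number of the three. Compound 4 `C=CCCCCOc1ncc(-c2cc(C(C)C)ccc2OC)n1C` keeps its chain and changes the aromatic ring: isopropyl in place of hydrogen on an aromatic carbon, para to a methoxy group. Among the measured compounds shown here, no measured step touches that ring, so the chain steps are only a loose guide: a 2.2-fold higher number from compound 1 to compound 2 (0.34 log units; beyond the scatter), a 2.8-fold lower number from compound 1 to compound 3 (0.44 log units; beyond the scatter) and a 6.0-fold lower number from compound 2 to compound 3 (0.78 log units; beyond the scatter). The last of these lengthens a hydrocarbon chain and is the closest parallel, so a modest move to a lower number seems likeliest. The expected change is a 1.6-fold lower number from compound 3 to compound 4 (0.20 log units; within the scatter), with the direction uncertain. Compound 4 is estimated at 2500 nM, with an expected range of 700 nM to 9000 nM.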

Compound 4, half-maximal inhibitory concentration: 3000 nM
For compound 4 the middle estimate is 1.2-fold (0.08 log units) below the measured one; low and high end bracket the measured number.
By their numbers in this assay, from the lowest: compounds 4 and 3 (each within the scatter of the next); then compound 1; then compound 2.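

In this assay, placing isopropyl on the aromatic carbon para to a methoxy group leaves compound 4 within the scatter of compound 3 (a 1.3-fold lower number from compound 3 to compound 4 (0.12 log units; within the scatter)). Among the compounds shown here, the earlier compounds differed only in the chain, so this is the first view of this ring position: here it takes isopropyl without a clear change in the number. Nothing available explains this result.

As far as these compounds go, whether an amine or a carboxylic acid at this carbon would shift the number remains open. So does whether isopropyl would behave the same way with the but-3-en-1-yl chain of compound 2.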